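The compounds below may be only part of what the source reports. "The series", "measured", "known", "first", "only" and "open" are said of these compounds alone.

Working notes on the series, read in a functional assay on MGC-803 cells (Homo sapiens) for inhibition, read by MTT assay, with a stated time of 48 h; on this read-out lower numbers stand for stronger inhibition and higher numbers for weaker inhibition. Compound 1 (`COc1ccc(CN(C(=O)C(C)Br)c2cc(OC)c(OC)c(OC)c2)cc1O`) gives 120 nM, compound 2 (`COc1ccc(CN(C(=O)CO)c2cc(OC)c(OC)c(OC)c2)cc1O`) gives 160 nM, and compound 3 (`COc1ccc(CN(C(=O)CN=[N+]=[N-])c2cc(OC)c(OC)c(OC)c2)cc1O`) gives 120 nM. Compound 3 stands level with compound 1, and all three values lie within the scatter of each other.

The next compound is compound 4 (`COc1ccc(CN(C(=O)C[Se]C#N)c2cc(OC)c(OC)c(OC)c2)cc1O`), which differs from compound 3 on a saturated chain carbon bound to a carbonyl carbon: a group of 3 heavy atoms (1 carbon, 1 nitrogen, 1 selenium; no ring) in place of a group of 3 heavy atoms (3 nitrogen; no ring), on a saturated chain carbon bound to a carbonyl carbon. The measured steps at this place are a 1.3-fold higher number from compound 1 to compound 2 (0.12 log units; within the scatter), no change at the digits printed from compound 1 to compound 3 (within the scatter) and a 1.3-fold lower number from compound 2 to compound 3 (0.12 log units; within the scatter). Going by these compounds, all three stay within the scatter, but none of them involves a selenium-bearing group, so the entering group remains untested. On this evidence, no step beyond the scatter is expected in this assay, and no direction is firmly indicated. The expected step is a 1.2-fold lower number from compound 3 to compound 4 (0.08 log units; within the scatter). The estimate for compound 4 is 100 nM, with an expected range of 40 nM to 250 nM.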

Compound 4, half-maximal inhibitory concentration: 270 nM
Estimate against measurement, compound 4: 2.7-fold (0.43 log units) below; measured number above the stated range.
By their numbers in this assay, from the lowest: compounds 1, 3, 2 and 4 (each within the scatter of the next, the first and the last beyond it).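

In this assay, going by these compounds alone, the selenium-bearing group gives the first step on this saturated chain carbon bound to a carbonyl carbon that passes beyond the scatter, a 2.3-fold higher number from compound 3 to compound 4 (0.35 log units; beyond the scatter), and the modest step of a 2.3-fold higher number from compound 1 to compound 4 (0.35 log units; beyond the scatter), on a carbonyl carbon, also passes beyond it. The step of a 1.7-fold higher number from compound 2 to compound 4 (0.23 log units; within the scatter) stays within the scatter, so the position is not indifferent to the group it carries, yet compound 4 separates only from compound 1 and compound 3. Nothing at hand accounts for this result.

Going by these compounds, whether the higher number follows the selenium or the nitrile end of the group stays open. Also open, on these data alone, is the reading with sulfur in place of selenium, or with an amine on this carbon.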